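Swapping an ether link for a benzylamine on a shared core

The source may report more compounds than this note shows. Statements on the series, on what has been measured and on what is new or still open speak of the compounds shown alone.

Three compounds measured so far:
Compound 1, `CCOC(=O)[C@H](CCC(=O)O)NC(=O)c1ccc(Sc2nc3cc(N)cc(N)c3nc2-c2ccccc2)cc1`, in a functional assay on BT-549 cells (Homo sapiens) for inhibition, read by sulforhodamine B assay, with a stated time of 48 h (a lower number here means that less compound is tolerated, a higher number that more compound is tolerated), gives only a limit, < 100000 nM, not a number.
Compound 2, `Nc1cc(N)c2nc(-c3ccccc3)c(Oc3ccc(F)cc3)nc2c1`, in this assay gives 81300 nM.
Compound 3, `COc1cc(CNc2nc3cc(N)cc(N)c3nc2-c2ccccc2)cc(OC)c1OC`, in this assay gives 27500 nM.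

Compound 2 gives the highest of the two numbers; compound 3 sits nearest, with a value lower by more than the scatter. Compound 4, `Nc1cc(N)c2nc(-c3ccccc3)c(NCc3ccc(F)cc3)nc2c1`, differs from compound 2 in one place: (4-fluorobenzyl)amino in place of 4-fluorophenoxy on an aromatic carbon. Within the data shown here, no measured pair shows this exact change, so its size is uncertain. Compound 3 also carries an amino link to a benzyl group and gives 27500 nM in this assay, which hints that a lower number may follow. The step of a 2.0-fold lower number from compound 2 to compound 4 (0.31 log units; beyond the scatter) is expected to be small and downward. Compound 4 is estimated at 40000 nM, with a range from 15000 nM to 100000 nM.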

Compound 4, concentration lethal to 50% of the cells: 6310 nM
Compound 4: the middle estimate sits 6.3-fold (0.80 log units) above what was measured; the measured number lies below the stated range.
By their numbers in this assay, from the lowest: compound 4; then compound 3; then compound 2.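

Replacing 4-fluorophenoxy with (4-fluorobenzyl)amino on the aromatic carbon next to the ring nitrogen gives a 13-fold lower number from compound 2 to compound 4 (1.11 log units; beyond the scatter) in this assay. Among these compounds, this is the first measured step at this position, and it shows that the group here can change the result by a large margin, with less of compound 4 tolerated by the cells.

The compounds shown cannot separate the effect of the nitrogen link from that of the added carbon, which a 4-fluorobenzyloxy or a 4-fluoroanilino group at this position would help to do. Compound 1 gives only a limit, so it cannot be ranked with the others: the limit of < 100000 nM in this assay, at which 1 of the 4 values shown sits.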